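The source may report more compounds than this note shows. Statements on the series, on what has been measured and on what is new or still open speak of the compounds shown alone.

In an assay for inhibition of Amine oxidase [flavin-containing] B (Rattus norvegicus) (on this read-out higher numbers stand for weaker inhibition and lower numbers for stronger inhibition), compound 3 `N#CCn1nc(-c2ccc(OCc3ccccc3)cc2)oc1=O` gives 60 nM. Compound 1 `COc1cccc(COc2ccc(-c3nn(CCC#N)c(=S)o3)cc2)c1` gives 100 nM, which lies within the scatter of compound 3, while compound 2 `N#CCCn1nc(-c2ccc(OCc3ccc(Cl)cc3)cc2)oc1=S` gives 690 nM, which lies beyond the scatter above compound 3. Compound 4 `CC(C#N)Cn1nc(-c2ccc(OCc3ccccc3)cc2)oc1=O` differs from compound 3 by 1-cyanoethyl in place of cyano on a saturated chain carbon bound to an aromatic nitrogen. Going by the values given here, no measured step touches this place: the only step, a 6.9-fold higher number from compound 1 to compound 2 (0.84 log units; beyond the scatter), concerns the group on the saturated chain carbon bound to an oxygen on an aromatic ring, and compounds 1 and 2 each differ from compound 3 in more than one place. With nothing measured at this position, the step in this assay is expected to be a 1.5-fold higher number from compound 3 to compound 4 (0.18 log units; within the scatter), within the scatter. Compound 4 is therefore estimated at 90 nM, with a range from 30 nM to 300 nM.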

Compound 4, half-maximal inhibitory concentration: 2400 nM
Compound 4: middle estimate off by 27-fold (1.43 log units), on the low side, and the stated range ends below it.
By their numbers in this assay, from the lowest: compounds 3 and 1 (each within the scatter of the next); then compound 2; then compound 4.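

In this assay, the change from cyano to 1-cyanoethyl on a saturated chain carbon bound to an aromatic nitrogen gives a 40-fold higher number from compound 3 to compound 4 (1.60 log units; beyond the scatter). Going by these compounds alone, this shows that inhibition is sensitive to the group at this place, which the earlier compounds could not show, as their only step concerned a different place. Nothing in the data given bears on why the number rises. The compounds shown leave open whether the rise follows the added carbons or the branch, and how an unbranched 2-cyanoethyl chain or an amine would read here on the same core.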